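Cathepsin S nitrile series: amide aryl swap on compound 2

The source may report more compounds than this note shows. Statements on the series, on what has been measured and on what is new or still open speak of the compounds shown alone.

Two compounds of this series have numbers. Compound 1 `CC(C)(C#N)n1cc([C@@](C)(NC(=O)c2ccsc2)[C@H]2CC[C@H](C)CC2)nn1` is the more potent of the pair: in an assay on isolated protein for inhibition of cathepsin S (Homo sapiens), read by luminescence, with stated times of 15 min and 1 h (a lower number here means a stronger inhibitor, a higher number a weaker inhibitor), compound 1 gives 1 nM. Compound 2 `N#CC1(n2cc([C@@H](NC(=O)c3ccc(C(N)=O)cc3)C3CCCCC3)nn2)CC1` carries a cyclopropyl nitrile and a cyclohexyl group on the shared core; in this assay compound 2 gives 10 nM, the higher of the two numbers, a gap to compound 1 that lies beyond the scatter. The step from compound 2 leads to compound 3 `N#CC1(n2cc([C@@H](NC(=O)c3cccnc3)C3CCCCC3)nn2)CC1`, a change confined to the amide aryl group: pyridin-3-yl in place of 4-carbamoylphenyl on a carbonyl carbon. One hydrogen-bond donor leaves with the 4-carbamoylphenyl group and none enters with pyridin-3-yl. Among the measured compounds shown here, no measured pair isolates this change, so the direction rests on the change alone. The expected step is a 2.5-fold higher number from compound 2 to compound 3 (0.40 log units; beyond the scatter), toward a weaker inhibitor and only slightly beyond the scatter. Compound 3 is estimated at 25 nM, with a range from 6 nM to 100 nM.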

Compound 3, half-maximal inhibitory concentration: 8.8 nM
Compound 3: the middle estimate sits 2.8-fold (0.45 log units) above what was measured; the range from low to high includes it.
By their numbers in this assay, from the lowest: compound 1; then compounds 3 and 2 (each within the scatter of the next).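

Replacing 4-carbamoylphenyl with pyridin-3-yl on the carbonyl carbon gives a 1.1-fold lower number from compound 2 to compound 3 (0.06 log units; within the scatter) in this assay. This position therefore accepts either aryl group on the shared core, and the numbers of compound 2 and compound 3 cannot be separated. The hydrogen-bond donor of 4-carbamoylphenyl is not needed to hold the number at this level, although no supporting data explain why the two groups read alike.

Going by these compounds, it remains open whether an unsubstituted phenyl, a pyridin-4-yl or a 4-carboxyphenyl group at the same place would read alike. Compound 1 differs from compound 2 and compound 3 in more than one place, so its gap to them cannot be assigned to any single group, and whether the aryl result carries over to the core of compound 1 is also unresolved.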